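The source may report more compounds than this note shows. Statements on the series, on what has been measured and on what is new or still open speak of the compounds shown alone.

Compound 3 `COc1cc(-n2cnc3ccc(-c4ccccc4)cc32)cc(OC)c1OC` stands as the higher of the two numbers in a functional assay on SGC-7901 cells (Homo sapiens) for antiproliferative activity, read by MTT assay, with a stated time of 72 h (on this read-out higher numbers stand for weaker inhibition and lower numbers for stronger inhibition), where compound 3 gives 290 nM. Its nearest neighbour, compound 1 `COc1cc(-n2cnc3ccc(-c4ccc([N+](=O)[O-])cc4)cc32)cc(OC)c1OC`, gives 79 nM in this assay. Compound 2 `COc1cc(-n2cnc3ccc(-c4ccccc4Cl)cc32)cc(OC)c1OC` reaches only a limit of the assay in this assay, > 10000 nM (the limit of > 10000 nM in this assay, at which 1 of the 3 values shown sits). The change to compound 4 `COc1cc(-n2cnc3ccc(-c4ccc(C)cc4)cc32)cc(OC)c1OC` is methyl in place of hydrogen on an aromatic carbon. Among the measured compounds shown here, two measured steps bear on it. The step of a 3.7-fold higher number from compound 1 to compound 3 (0.56 log units; beyond the scatter) shows that losing the nitro group raises the number modestly, so a group entering in its stead might recover part of that ground. The step of an at least 34-fold lower number from compound 2 to compound 3 (1.53 log units; beyond the scatter), involving the chloro of compound 2, is large, but it does not speak directly to a methyl group. Since methyl is not nitro, only a small gain is expected, and the expected step of a 1.5-fold lower number from compound 3 to compound 4 (0.16 log units; within the scatter) reflects this. Compound 4 is therefore expected to give 200 nM in this assay, with a range from 70 nM to 600 nM.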

Compound 4, half-maximal inhibitory concentration: 200 nM
For compound 4 middle estimate and measured number coincide at the digits printed; measured number inside the range.
By their numbers in this assay, from the lowest: compound 1; then compounds 4 and 3 (each within the scatter of the next). At a limit, above all of these: compound 2.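

The step of a 1.5-fold lower number from compound 3 to compound 4 (0.16 log units; within the scatter) does not separate methyl from hydrogen on this aromatic carbon, para to a large group. Nitro at the same place stays apart from methyl, with the step of a 2.5-fold higher number from compound 1 to compound 4 (0.40 log units; beyond the scatter), so among these compounds the position does not treat every group alike. The change from 2-chlorophenyl to 4-methylphenyl gives the step of an at least 50-fold lower number from compound 2 to compound 4 (1.69 log units; beyond the scatter), which can only be read as a bound, as compound 2 stands at a limit of the assay: the limit of > 10000 nM in this assay, at which 1 of the 4 values shown sits.

The compounds shown do not tell where an amine or a carboxylic acid at this place would stand against nitro and methyl. They also leave the chloro group and its place unseparated, which a 4-chlorophenyl group would address.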